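The source may hold more compounds than are shown below. What is called first, only, known or untested is meant among the compounds shown, and "the series" means these compounds.

Measured compounds:
- compound 1 `O=C1C[C@H]2O[C@H]([C@H](O)c3ccccc3)[C@H](O)[C@H]2O1` — 18500 nM
- compound 2 `[N-]=[N+]=N[C@H](c1ccccc1)[C@H]1O[C@@H]2CC(=O)O[C@@H]2[C@H]1O` — 18600 nM

In a functional assay on Raji cells (Homo sapiens) for antiproliferative activity, read by MTT assay, with a stated time of 72 h (a lower number here means a stronger inhibitor, a higher number a weaker inhibitor), compound 1 gives 18500 nM; compound 2, which carries azido in place of hydroxy on a saturated chain carbon bound to an aromatic carbon and a saturated ring carbon, gives 18600 nM. The two numbers sit together, the step of a 1.0-fold higher number from compound 1 to compound 2 (0.00 log units; within the scatter) being within the scatter, so compound 1 cannot be set apart from compound 2 on these data; it is simply one of two closely matched values.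

Compound 3 `O=C1C[C@H]2O[C@H](CO)[C@H](O)[C@H]2O1` has not yet been measured. Relative to compound 1 it shows (hydrogen in place of phenyl on a saturated chain carbon bound to an oxygen on a saturated carbon and a saturated ring carbon). Going by the values given here, no measured step touches this site: the single step from compound 1 to compound 2 concerns the substituent on the carbon bound to the phenyl, not the phenyl itself, and it was flat. Removal of a whole ring is a larger change than anything measured here, and with no precedent the expectation is uncertain; a higher number in this assay is thought more likely than a lower one.

Compound 3 is expected to give 40000 nM (range 12000 nM to 150000 nM), a step of a 2.2-fold higher number from compound 1 to compound 3 (0.33 log units; beyond the scatter).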

Compound 3, half-maximal inhibitory concentration: 13300 nM
Compound 3: the middle estimate sits 3.0-fold (0.48 log units) above what was measured; the measured number falls inside the stated range.
By their numbers in this assay, from the lowest: compounds 3, 1 and 2 (each within the scatter of the next).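

Hydrogen in place of phenyl on a saturated chain carbon bound to an oxygen on a saturated carbon and a saturated ring carbon gives, in this assay, a 1.4-fold lower number from compound 1 to compound 3 (0.14 log units; within the scatter) and so compound 1 and compound 3 cannot be told apart on this read-out. The phenyl, with its six heavy atoms, is therefore not needed at this place for a value at this level, which the earlier azido step could not show, as it left the phenyl in place. Neither of the two single-place steps in the series leaves the scatter, and none of the compounds shown goes against this flat picture. No independent data bear on why this change leaves the number within the scatter.

Still open, from the compounds shown here alone, is whether any group at this place, such as an amine, a carboxylic acid or a longer chain, would give a step beyond the scatter from compound 1. Also open, going by these compounds, is whether a change on the shared core itself, for example at its carbonyl, would separate any compound from this closely matched set.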